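Swapping the Aryl Group on a Chromene Chalcone

This account rests on a few compounds, and the source may have more. Where it says the series, first, only, none or still open, it means among the compounds named here.

Of the compounds shown here, three sharing one core have been tested in a functional assay on HepG2 cells (Homo sapiens) for antiproliferative activity, read by MTT assay, with a stated time of 24 h; a lower number here means a stronger inhibitor, a higher number a weaker inhibitor. Compound 1 `COc1ccc(C(=O)/C=C/c2ccc(N(c3ccccc3)c3ccccc3)cc2)c2c1C=CC(C)(C)O2` carries a diphenylamino group on its outer ring. Compound 1 reaches only the limit of > 10000 nM in this assay, which is a limit rather than a number. Compound 2 `COc1ccc(C(=O)/C=C/c2cccc([N+](=O)[O-])c2)c2c1C=CC(C)(C)O2` carries a nitro group instead, and in this assay compound 2 gives 2830 nM. Compound 3 `COc1ccc(C(=O)/C=C/c2cccc(C(F)(F)F)c2)c2c1C=CC(C)(C)O2` carries a trifluoromethyl group; in this assay compound 3 again reaches only the limit of > 10000 nM. Compound 2 is therefore the only one of the three with a real number, the other two sitting at the limit of > 10000 nM in this assay, at which 2 of the 3 values shown sit.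

Compound 4 `COc1ccccc1/C=C/C(=O)c1ccc(OC)c2c1OC(C)(C)C=C2` has not been measured. It differs from compound 2 in one place: 2-methoxyphenyl in place of 3-nitrophenyl on a double-bonded chain carbon bound to a double-bonded chain carbon. Going by the values given here, the one measured step that touches this position is an at least 3.5-fold higher number from compound 2 to compound 3 (0.54 log units; beyond the scatter), showing that replacing the nitro group cost activity. Whether a methoxy group behaves the same way cannot be read from the data, so a step toward a weaker number is expected, perhaps large enough to reach the limit again. For compound 4 the expected result is 8000 nM, within a range from 2500 nM to 30000 nM. The expected change is therefore a 2.8-fold higher number from compound 2 to compound 4 (0.45 log units; beyond the scatter).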

Compound 4, half-maximal inhibitory concentration: > 10000 nM
Compound 4 gave a limit, no number; the forecaster's own chance of this, stated with the estimate: 50%; middle value at least 1.2-fold (0.09 log units) from the limit.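

Replacing 3-nitrophenyl with 2-methoxyphenyl on a double-bonded chain carbon bound to a double-bonded chain carbon gives an at least 3.5-fold higher number from compound 2 to compound 4 (0.54 log units; beyond the scatter) in this assay. Going by these compounds alone, until now the only step at this position was an at least 3.5-fold higher number from compound 2 to compound 3 (0.54 log units; beyond the scatter), a loss that might have belonged to the trifluoromethyl group alone, but a second and quite different incoming group, methoxy, now brings a loss beyond the scatter as well, so the loss is not tied to one replacement. Among the four compounds shown, compound 2 is the only one with a real number, and each of the other aryl groups ends at the same limit: the limit of > 10000 nM in this assay, at which 3 of the 4 values shown sit.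

Going by these compounds, the steps among compound 1, compound 3 and compound 4 cannot be read, so these three cannot be ranked against one another, and the true size of each loss from compound 2 remains unknown. Also open, on these data alone, is whether the nitro group itself is needed for a measurable value, or whether another group on this ring, such as an amine, a nitrile or a carboxylic acid, would also give one.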